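The source may hold more compounds than are shown below. What is called first, only, known or untested is meant among the compounds shown, and "the series" means these compounds.

Working notes on the thiourea series. Compound 1 `NC(=S)Nc1cccc(Oc2ccccc2)c1` sits at a limit in an ADME assay on Ava5 cells (Homo sapiens) for cytotoxicity (a higher number here means that more compound is tolerated, a lower number that less compound is tolerated), giving > 50000 nM; this is a limit and not a number, namely (the limit of > 50000 nM in this assay, at which 1 of the 3 values shown sits). Compound 2 `NC(=S)Nc1cccc(OCCCCCc2ccccc2)c1` gives 22000 nM. Compound 3 `NC(=S)Nc1cccc(OCCCCCOc2ccc(Cl)cc2)c1` gives 7000 nM, the lowest of the two numbers, with compound 2 nearest. Within the data shown here, the single measured step, a 3.1-fold lower number from compound 2 to compound 3 (0.50 log units; beyond the scatter), is the only guide. Compound 4 `NC(=S)Nc1cccc(OCCCCCOc2ccc(-c3ccco3)cc2)c1` differs from compound 3 by furan-2-yl in place of chloro on an aromatic carbon. Among the measured compounds shown here, no measured step replaces chloro with furan-2-yl; the one step seen ran lower for 4-chlorophenoxy in place of phenyl, so for compound 4 a further lowering of comparable or smaller size is expected, namely a 1.8-fold lower number from compound 3 to compound 4 (0.24 log units; within the scatter). Compound 4 is estimated at 4000 nM, with a range from 1500 nM to 10000 nM.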

Compound 4, half-maximal cytotoxic concentration: 11000 nM
Compound 4: the middle estimate sits 2.8-fold (0.44 log units) below what was measured; measured number outside the range, above it.
By their numbers in this assay, from the lowest: compounds 3, 4 and 2 (each within the scatter of the next, the first and the last beyond it). At a limit, above all of these: compound 1.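

On the aromatic carbon para to a large group, furan-2-yl in place of chloro gives a 1.6-fold higher number from compound 3 to compound 4 (0.20 log units; within the scatter) in this assay. Among these compounds, this position therefore accepts a five-membered aromatic ring with a hetero atom, and the number stays within the scatter of the chloro compound, which the earlier compounds, all without a substituent change at this carbon, could not show. Nothing at hand accounts for this step.

On these data alone, whether an amine or a carboxylic acid on this carbon would leave the number in this assay as little changed stays open. So does the effect of a longer chain between the two oxygens.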